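A few compounds are considered here, and "the series" means these few. Any claim that something is new, unique, unknown or untested is made for them only; others in the source may bear on it.

Measured so far in a functional assay on Rec1 cells (Homo sapiens) for inhibition, read by luminescence and CellTiter-Glo, with a stated time of 72 h; on this read-out lower numbers stand for stronger inhibition and higher numbers for weaker inhibition:
- compound 1 `CCOC(=O)c1cc(-c2ccc(Oc3ccccc3)cc2)nn1Cc1cccc(NC(=O)CCl)c1`: 400 nM
- compound 2 `O=C(CCl)Nc1cccc(Cn2nc(-c3ccc(Oc4ccccc4)cc3)cc2C(=O)O)c1`: 7100 nM

For the measured compounds named here, compound 1 holds the lower of the two numbers, and compound 2 is its only neighbour. Going by the values given here, the single measured step is an 18-fold higher number from compound 1 to compound 2 (1.25 log units; beyond the scatter). That is a large step, but it replaces the ethyl group of the ester with hydrogen and leaves the chloromethyl carbonyl amino group untouched.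

The next compound, compound 3 `CCOC(=O)c1cc(-c2ccc(Oc3ccccc3)cc2)nn1Cc1ccc(NC(=O)CCl)cc1`, has not yet been measured. It keeps the ester of compound 1 and changes something else: 4-(((chloromethyl)carbonyl)amino)phenyl in place of 3-(((chloromethyl)carbonyl)amino)phenyl on a saturated chain carbon bound to an aromatic nitrogen. The two compounds have the same atoms, joined differently. Among the compounds with values here, no measured pair tests this kind of move, so its size is poorly constrained. The step to compound 2 shows only that this series can move by a large amount in this assay after one local change. A modest loss is the working expectation, with no gain assumed. The expected step is a 2.0-fold higher number from compound 1 to compound 3 (0.30 log units; within the scatter), and it may not clear the scatter. For compound 3 the estimated value is 800 nM, with an expected range of 200 nM to 4000 nM.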

Compound 3, half-maximal inhibitory concentration: 400 nM
Compound 3: middle estimate off by 2.0-fold (0.30 log units), on the high side; the range from low to high includes it.
By their numbers in this assay, from the lowest: compounds 1 and 3 (each within the scatter of the next); then compound 2.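

In this assay, 4-(((chloromethyl)carbonyl)amino)phenyl in place of 3-(((chloromethyl)carbonyl)amino)phenyl on a saturated chain carbon bound to an aromatic nitrogen gives no change at the digits printed from compound 1 to compound 3 (within the scatter). For the compounds shown here, the earlier pair tested only the ester, with an 18-fold higher number from compound 1 to compound 2 (1.25 log units; beyond the scatter), so this is the first reading on the ring bearing the chloromethyl carbonyl amino group: with the ethyl ester kept, this read-out does not separate the two arrangements, and the series is sensitive to the ester change but not, in this one pair, to this change of connectivity. Nothing available bears on why the two arrangements read alike.

From the compounds shown here alone, it remains open whether the same indifference holds with the free acid of compound 2, since this single pair carries the ethyl ester throughout. Going by these compounds, it also remains open how much of the reading depends on the chloromethyl carbonyl group itself, a question that an acetyl amide or an acrylamide in its place, on either arrangement of the phenyl ring, would address.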